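Diaryl urea series on MCF7 cells: notes toward compound 4

The source may report more compounds than this note shows. Statements on the series, on what has been measured and on what is new or still open speak of the compounds shown alone.

Compound 1 `CCNc1cc(-c2ccc(NC(=O)Nc3cccc(Cl)c3)cc2C)ccn1` and compound 2 `CCNc1cc(-c2ccc(NC(=O)Nc3ccc(C(F)(F)F)cc3)cc2C)ccn1` share one core and differ only at the urea end. In a functional assay on MCF7 cells (Homo sapiens) for cytotoxicity, read by MTT assay, with a stated time of 24 h (on this read-out higher numbers stand for weaker inhibition and lower numbers for stronger inhibition), compound 1 gives 4180 nM, and in this assay compound 2 gives 6870 nM. The change between them is 4-(trifluoromethyl)phenyl in place of 3-chlorophenyl on an amide-type nitrogen and the step it made is a 1.6-fold higher number from compound 1 to compound 2 (0.22 log units; within the scatter).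

Compound 3 `CCCNc1cc(-c2ccc(NC(=O)Nc3cccc(Cl)c3)cc2C(F)(F)F)ccn1` carries a different core; the difference between the core of compound 3 and the core of compound 1 is not broken down here. In this assay compound 3 gives 8230 nM, which sits within the scatter of compound 2 and of compound 1, so no order among the three is claimed.

Compound 4 `CCCNc1cc(-c2ccc(NC(=O)Nc3ccc(C(F)(F)F)cc3)cc2C(F)(F)F)ccn1` is not yet measured. It relates to compound 3 exactly as compound 2 relates to compound 1: the change is 4-(trifluoromethyl)phenyl in place of 3-chlorophenyl on an amide-type nitrogen, and the place it occurs is worded the same in both pairs, so this is the same change on a second core. Among the measured compounds shown here, the only guide to its size is the single step from compound 1 to compound 2, which stayed within the scatter; with one example and no second core to check against, the expectation is a step of about the same small size, a 1.6-fold higher number from compound 3 to compound 4 (0.20 log units; within the scatter), because the one measured case gave a 1.6-fold higher number from compound 1 to compound 2 (0.22 log units; within the scatter).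

The estimate for compound 4 in this assay is therefore 13000 nM, expected to lie between 6000 nM and 30000 nM.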

Compound 4, half-maximal inhibitory concentration: 7680 nM
Beside the measured number, compound 4's estimate is 1.7-fold (0.23 log units) above it, within the range that was stated.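

In this assay, putting 4-(trifluoromethyl)phenyl in place of 3-chlorophenyl on the amide-type nitrogen gives a 1.1-fold lower number from compound 3 to compound 4 (0.03 log units; within the scatter), so on the second core the step again stays within the scatter. Set side by side, the two steps cannot be told apart, and their opposite directions carry no weight: the same change on two cores in this assay, a 1.6-fold higher number (0.22 log units; within the scatter) from compound 1 to compound 2 and a 1.1-fold lower number (0.03 log units; within the scatter) from compound 3 to compound 4, 1.8-fold (0.25 log units) apart, within the scatter of two such steps. Among the compounds shown here, this shows that, on these two cores, the change carries over with no step distinguishable from the scatter; it does not show that the change is without effect in general, that it would behave the same way on a third core, or that the two cores respond identically, and two pairs are too few to support a rule for the series.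

Still open, on these data alone, is whether any other group at the urea end, such as a phenyl ring bearing a carboxylic acid or an amine, or a cyclohexyl ring in place of the phenyl ring, would move the number beyond the scatter. Also open is how the ethyl and propyl chains and the methyl and trifluoromethyl groups of the two cores each bear on the read-out, as no pair shown isolates either difference.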